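Trimming a benzyl sulfide to a propyl sulfide

The source may hold more compounds than are shown below. What is called first, only, known or untested is meant among the compounds shown, and "the series" means these compounds.

Measured compounds:
- compound 1, `Cc1cc(Nc2ccn(Cc3cccc4ccccc34)n2)n2nc(SCc3ccc(Br)cc3)nc2n1`: 4310 nM
- compound 2, `Cc1cc(Nc2cc(-c3ccccc3)[nH]n2)n2nc(SCc3ccccc3Br)nc2n1`: 3020 nM

Within the data shown here, in a functional assay on MCF7 cells (Homo sapiens) for inhibition, read by MTT assay, with a stated time of 72 h (a higher number here means a weaker inhibitor, a lower number a stronger inhibitor), compound 2 gives 3020 nM, the lowest of the two numbers so far. In this assay compound 1 gives 4310 nM, and the gap between compound 1 and compound 2 lies within the scatter, so the two compounds cannot be ranked against each other.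

Compound 3, `CCCSc1nc2nc(C)cc(Nc3cc(-c4ccccc4)[nH]n3)n2n1`, has not yet been tested in this assay. It differs from compound 2 in one place:

ethyl in place of 2-bromophenyl on a saturated chain carbon bound to a sulfur

Among the measured compounds shown here, no measured pair shows what removing the ring from this sulfur-bound chain does. For the measured compounds named here, the only guidance is that compound 1 and compound 2, which carry different groups on this sulfur and elsewhere, sit within the scatter of each other. The step from compound 2 to compound 3 in this assay is expected to be a mild weakening, about a 1.8-fold higher number from compound 2 to compound 3 (0.26 log units; within the scatter), though a result within the scatter would not surprise. Compound 3 is estimated at 5500 nM, with a range from 2000 nM to 16000 nM.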

Compound 3, half-maximal inhibitory concentration: > 50000 nM
Compound 3 ended at the assay's limit; the forecaster's own chance of this, stated with the estimate: 10%; middle value at least 9.0-fold (0.95 log units) from the limit.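

In this assay compound 3 gives > 50000 nM, which is a limit of the assay and not an exact number. Going from 2-bromobenzyl to propyl on the sulfur, with the rest of the molecule unchanged, produces an at least 16-fold higher number from compound 2 to compound 3 (1.21 log units; beyond the scatter), so the group at this position strongly affects the read-out, and a short saturated chain does not stand in for the brominated ring. The true size of this step cannot be read, and the printed step is only a minimum: the limit of > 50000 nM in this assay, at which 1 of the 3 values shown sits.

The compounds shown do not separate the part played by the ring from that played by its bromine, and a plain benzyl group on the sulfur would speak to that. They also leave open whether a longer chain, such as hexyl, would bring the number back towards that of compound 2.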